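The source may report more compounds than this note shows. Statements on the series, on what has been measured and on what is new or still open speak of the compounds shown alone.

Compound 3 `O=C(Nc1ccc(Oc2ccnc3[nH]ccc23)c(F)c1)c1cc(-c2ccccc2)ncn1` gives 40 nM in a functional assay on PC-3 cells (Homo sapiens) for cytotoxicity, read by MTT assay, with a stated time of 72 h (on this read-out higher numbers stand for weaker inhibition and lower numbers for stronger inhibition), the lowest of the three numbers at hand. Compound 1 `O=C(Nc1ccc(Oc2ccnc3[nH]ccc23)cc1)c1cc(-c2ccccc2)ncn1` gives 240 nM, and the one-place step a 6.0-fold lower number from compound 1 to compound 3 (0.78 log units; beyond the scatter) separates them. Compound 2 `Cc1ccc(-c2ccnc(C(=O)Nc3ccc(Oc4ccnc5[nH]ccc45)c(F)c3)n2)cc1` gives 520 nM; it differs from compound 3 in more than one place, so only the two values themselves can be compared. Compound 4 `O=C(Nc1ccc(Oc2ccnc3[nH]ccc23)c(F)c1)c1cc(-c2ccc(Cl)cc2)ncn1` carries the change (chloro in place of hydrogen on an aromatic carbon), para to a large group. For the measured compounds named here, no measured step touches this phenyl ring, and the methyl-bearing compound 2 cannot be read as a single step. Compound 4 is therefore expected to sit close to compound 3, with a 1.3-fold higher number from compound 3 to compound 4 (0.10 log units; within the scatter) not beyond the scatter. The estimate for compound 4 is 50 nM, within 15 nM to 160 nM.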

Compound 4, half-maximal inhibitory concentration: 3200 nM
Compound 4: the middle estimate sits 64-fold (1.81 log units) below what was measured; measured number outside the range, above it.
By their numbers in this assay, from the lowest: compound 3; then compound 1; then compound 2; then compound 4.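

The change from phenyl to 4-chlorophenyl, para to a large group, brings an 80-fold higher number from compound 3 to compound 4 (1.90 log units; beyond the scatter) in this assay, so this ring, untouched by any earlier one-place step, is a place where one added atom can move the number strongly. This step is larger than a 6.0-fold lower number from compound 1 to compound 3 (0.78 log units; beyond the scatter) and runs in the opposite direction. Nothing at hand gives a reason for the loss.

From the compounds shown here alone, whether it belongs to chloro alone or would also follow a methoxy or an amine at this place stays open. Compound 2 carries a methyl on this ring but differs in more than one place, so it cannot settle the question.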